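Working notes: bromo for nitro on a shared core

The compounds below may be only part of what the source reports. "The series", "measured", "known", "first", "only" and "open" are said of these compounds alone.

Measured so far:
compound 1, `CCn1c(/C=C2/C(=O)Nc3ccc(Br)cc32)nc2ccccc21`, > 50000 nM
compound 2, `CCn1c(/C=C2/C(=O)Nc3ccc(C)cc32)nc2ccccc21`, > 50000 nM
compound 3, `Cn1c(/C=C2/C(=O)Nc3ccc([N+](=O)[O-])cc32)nc2ccccc21`, "not determined" (no result reported)

In a functional assay on HGC cells (Homo sapiens) for cytotoxicity, read by MTT assay, with a stated time of 48 h (a higher number here means a weaker inhibitor, a lower number a stronger inhibitor), compound 1 gives > 50000 nM, which is a limit of the assay and not a number. In this assay compound 2 gives > 50000 nM, again a limit. Within the data shown here, the one step between measured compounds, a step that the two limits leave unreadable from compound 1 to compound 2, therefore cannot be read for size. Among the measured compounds shown here, for compound 3 no result was reported in this assay, so compound 3 stands without a number of its own, and the only evidence is the limit of > 50000 nM in this assay, at which 2 of the 3 values shown sit.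

Compound 4, `Cn1c(/C=C2/C(=O)Nc3ccc(Br)cc32)nc2ccccc21`, is the next target. The change from compound 3 to compound 4 is bromo in place of nitro on an aromatic carbon. For the measured compounds named here, no measured step bears on this change, so no size or direction can be drawn for this assay from the steps; what can be said is that compound 1 also carries bromo on the same carbon and gives > 50000 nM, a limit. Compound 4 is estimated at 60000 nM in this assay, with an expected range from 20000 nM to 200000 nM, and most likely again only a limit.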

Compound 4, half-maximal inhibitory concentration: > 50000 nM
Compound 4: only a limit was reported (the forecaster's own chance of this, stated with the estimate: 80%); the middle value lies beyond the limit too.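

No new step can be read: compound 1 and compound 4 both stand at a limit of the assay, so the step between them has no readable size. The compounds shown leave open whether any change on the shared core gives an actual number in this assay: the limit of > 50000 nM in this assay, at which 3 of the 4 values shown sit.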